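This account rests on a few compounds, and the source may have more. Where it says the series, first, only, none or still open, it means among the compounds named here.

Measured so far:
compound 1 `COc1cc2c(cc1OC)C(c1cccc(N)c1)=NN=C(S)C2` gives 18.8 umol/kg
compound 2 `COc1cc2c(cc1OC)C(c1ccc([N+](=O)[O-])cc1)=NN=C(S)C2` gives 93.4 umol/kg

In a functional assay on the whole organism with Mus musculus as the target (a lower number here means that less compound is needed, a higher number that more compound is needed for the effect), compound 2 stands at 93.4 umol/kg and so has the higher of the two numbers, with a gap to compound 1 that lies beyond the usual scatter. Compound 3 `COc1cc2c(cc1OC)C(c1ccc(Br)cc1)=NN=C(S)C2` keeps the shared core and carries bromo in place of nitro on an aromatic carbon, para to a large group (bromo in place of nitro on an aromatic carbon). Among the compounds with values here, no measured pair shows this swap alone, so any expectation is loose. Within the data shown here, compound 1 at 18.8 umol/kg and compound 2 at 93.4 umol/kg are the only guides, and an expected number between them seems likeliest. The estimated change a 2.3-fold lower number from compound 2 to compound 3 (0.37 log units; beyond the scatter) is expected to be a modest fall in this assay and only a little beyond the usual scatter. The estimate for compound 3 is 40 umol/kg (expected range 12 umol/kg to 130 umol/kg).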

Compound 3, dose for half-maximal effect: 52.1 umol/kg
Compound 3: middle estimate off by 1.3-fold (0.11 log units), on the low side; the measured number falls inside the stated range.
By their numbers in this assay, from the lowest: compound 1; then compounds 3 and 2 (each within the scatter of the next).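

In this assay, bromo in place of nitro gives a 1.8-fold lower number from compound 2 to compound 3 (0.25 log units; within the scatter), so at this place on the aromatic ring, para to a large group, these two quite different groups cannot be told apart. The other step, a 2.8-fold higher number from compound 1 to compound 3 (0.44 log units; beyond the scatter), lies beyond the scatter, but it exchanges 3-aminophenyl for 4-bromophenyl, so the group and its place on the ring change together and the gap cannot be assigned to either one alone. The data offer no independent measurement that would explain these numbers.

From the compounds shown here alone, it remains open whether an amine or a carboxylic acid at this same place would also fall within the scatter of bromo and nitro. A 3-bromophenyl or 4-aminophenyl group would be needed to separate the effect of the group from the effect of its place on the ring.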